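The compounds below may be only part of what the source reports. "The series", "measured", "known", "first", "only" and "open" are said of these compounds alone.

Measured so far:
compound 1 `Cc1ccc(-c2nnc(SCCn3c([N+](=O)[O-])cnc3C)o2)cc1` — 15500 nM
compound 2 `Cc1ncc([N+](=O)[O-])n1CCSc1nnc(-c2ccc(N)cc2)o1` — 19800 nM

Both numbers come from a functional assay on MCF7 cells (Homo sapiens) for cytotoxicity, read by MTT assay, with a stated time of 48 h; on this read-out lower numbers stand for stronger inhibition and higher numbers for weaker inhibition. Compound 1 holds the lowest of the two numbers, but its nearest neighbour is compound 2, and the step of a 1.3-fold higher number from compound 1 to compound 2 (0.11 log units; within the scatter) lies within the scatter, so the two compounds cannot be ordered against each other.

Compound 3 `Cc1ncc([N+](=O)[O-])n1CCSc1nnc(-c2ccco2)o1` is the next unmeasured member. It differs from compound 1 as follows: furan-2-yl in place of 4-methylphenyl on an aromatic carbon. Among the measured compounds shown here, the single measured step, a 1.3-fold higher number from compound 1 to compound 2 (0.11 log units; within the scatter), concerns an alteration of the 4-methylphenyl group rather than the exchange of that whole group for another ring, so it bears on the new change only loosely; it shows that one alteration of that group left the number in this assay essentially where it was. For the measured compounds named here, no measured step covers replacing the six-membered aromatic ring with furan-2-yl. On this basis no step beyond the scatter is expected in this assay in either direction, with a wide range to reflect the missing precedent. For compound 3 the estimate is 18000 nM (range 7000 nM to 45000 nM), which means an expected step of a 1.2-fold higher number from compound 1 to compound 3 (0.06 log units; within the scatter).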

Compound 3, half-maximal inhibitory concentration: 29500 nM
Compound 3: middle estimate off by 1.6-fold (0.21 log units), on the low side; the range from low to high includes it.
By their numbers in this assay, from the lowest: compounds 1, 2 and 3 (each within the scatter of the next).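

Exchanging the whole 4-methylphenyl group for furan-2-yl on this aromatic carbon gives a 1.9-fold higher number from compound 1 to compound 3 (0.28 log units; within the scatter) in this assay, so this position has now been probed by a change of ring, not only by an alteration of the group on the six-membered ring. Set against the 4-aminophenyl group of compound 2, the same ring gives a 1.5-fold higher number from compound 2 to compound 3 (0.17 log units; within the scatter) in this assay, and neither step separates furan-2-yl from the six-membered rings. A five-membered aromatic ring with 1 hetero atom therefore sits within the scatter of both 4-substituted phenyl groups on this aromatic carbon, and the data at hand offer no explanation for this flat picture.

As far as these compounds go, all three compounds carry an aromatic ring at this place, so it remains open whether a saturated ring such as cyclohexyl, a plain amine or a carboxylic acid on this aromatic carbon would give a step beyond the scatter. Also open is whether a longer chain elsewhere in the shared core would move the number, as the compounds shown differ only at this one place.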